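Smaller Chain on the Pyrazole Nitrogen: Expected Solubility Gain

A few compounds are considered here, and "the series" means these few. Any claim that something is new, unique, unknown or untested is made for them only; others in the source may bear on it.

Measured compounds:
- compound 1, `CC(=O)Nc1cc(-c2ccc(N(C)C(=O)c3c(F)cccc3Cl)c(N3CC4CC4C3)c2)n(CC(C)(C)C)n1`: 0.8 ug/mL
- compound 2, `CC(=O)Nc1cc(-c2ccc(N(C)C(=O)c3c(C)cccc3F)c(N3CC4CC4C3)c2)n(C(C)C)n1`: 17 ug/mL
- compound 3, `CC(=O)Nc1cc(-c2cnc(N(C)C(=O)c3c(F)cccc3Cl)c(N3CC4CC4C3)c2)n(C(C)C)n1`: 48 ug/mL

Of the compounds shown here, three sharing one core have been tested in a physicochemical assay for solubility, measured as kinetic solubility; a lower number here means a less soluble compound, a higher number a more soluble compound. Compound 1 gives 0.8 ug/mL in this assay, the lowest of the three numbers. Compound 2 gives 17 ug/mL, a higher number that lies beyond the scatter of repeated measurements, and compound 3 gives 48 ug/mL, the highest of the three and furthest from compound 1. Compounds 2 and 3 differ from compound 1 in more than one place, so no single change can be read from those gaps.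

The step now followed leads from compound 1 to compound 4, `CC(=O)Nc1cc(-c2ccc(N(C)C(=O)c3c(F)cccc3Cl)c(N3CC4CC4C3)c2)n(CC2CC2)n1`, which has not yet been measured in this assay. The change is this:

cyclopropyl in place of tert-butyl on a saturated chain carbon bound to an aromatic nitrogen

The group that leaves carries one more heavy atom than the group that enters, and the ring that enters is a small one. For a compound of this shape, a smaller chain on the aromatic nitrogen is expected to move the number upward, though by a modest amount. Compound 4 is estimated at 3 ug/mL, within a range from 1 ug/mL to 10 ug/mL. This estimate means a step of a 3.8-fold higher number from compound 1 to compound 4 (0.57 log units; beyond the scatter), expected to be upward and probably beyond the scatter.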

Compound 4, solubility: 10.1 ug/mL
The estimate for compound 4 lay 3.4-fold (0.53 log units) below the measured number; the whole stated range lies below it.
By their numbers in this assay, from the lowest: compound 1; then compounds 4 and 2 (each within the scatter of the next); then compound 3.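

In this assay, within the data shown here, this is the first pair of compounds that differ in one place, so a single change can finally be read: cyclopropyl in place of tert-butyl, which cut one bond further out reads neopentyl to cyclopropylmethyl, gives a 13-fold higher number from compound 1 to compound 4 (1.10 log units; beyond the scatter) and counts as a large step. Among these compounds, the position on a saturated chain carbon bound to an aromatic nitrogen is therefore not a silent one, since the number moves this far with the rest of the core of compound 1 held fixed, something the earlier compounds, with their several differences, could not show. No measurement shown here accounts for the size of this step.

The change removes one heavy atom and adds a ring in the same stroke, so these compounds do not separate the two, and an open chain such as isobutyl would be the natural partner for that comparison. As far as these compounds go, it also remains open how a chain ending in an amine or a hydroxyl would read at this position, and whether the same step would appear on a different core.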